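The source may hold more compounds than are shown below. What is called first, only, known or untested is meant among the compounds shown, and "the series" means these compounds.

Compound 1 `Fc1cccc(-c2nc(Nc3cccc(Cl)c3)c3cc(F)ccc3n2)c1` opens this small set. In a functional assay on COLO 205 cells (Homo sapiens) for cytotoxicity, read by MTT assay, with a stated time of 48 h (a higher number here means a weaker inhibitor, a lower number a stronger inhibitor), compound 1 gives only a limit, > 50000 nM. Compound 2 `Oc1cccc(Nc2nc(-c3cccc(F)c3)nc3ccc(F)cc23)c1` carries a hydroxy in place of chloro on an aromatic carbon. In this assay compound 2 likewise gives only a limit, > 50000 nM. The step that the two limits leave unreadable from compound 1 to compound 2 cannot be read, since both values sit at the limit of > 50000 nM in this assay, at which 2 of the 2 values shown sit. Compound 2 thus stands at the edge of what this assay can report, with no number of its own. Compound 3 `Nc1ccccc1Nc1nc(-c2cccc(F)c2)nc2ccc(F)cc12` differs from compound 2 by 2-aminophenyl in place of 3-hydroxyphenyl on a nitrogen on an aromatic ring. Among the compounds with values here, no measured step tells how such an exchange moves the read-out, and the single step available is itself unreadable. Compound 3 is therefore expected to show a step that the limit leaves unreadable from compound 2 to compound 3 of no readable size, most likely ending again at a limit. Compound 3 is estimated at 60000 nM, within a range from 20000 nM to 200000 nM.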

Compound 3, half-maximal inhibitory concentration: > 50000 nM
Compound 3: no number, only a limit; the forecaster's own chance of this, stated with the estimate: 80%; the middle value lies beyond the limit too.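

Compound 3 also gives only a limit in this assay, so its steps from compound 1 and compound 2 cannot be read: the limit of > 50000 nM in this assay, at which 3 of the 3 values shown sit.

The compounds shown leave open how strongly any of the three acts in this assay, and whether exchanging the group on the nitrogen changes that at all.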